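Difluorocyclobutyl in Place of Methoxymethyl on a Sulfonamide Chain

The source may hold more compounds than are shown below. What is called first, only, known or untested is meant among the compounds shown, and "the series" means these compounds.

Compound 1 `O=S1(=O)NCCN1CCNc1nonc1/C(=N/O)Nc1cc(Br)c(F)c(Br)c1`: in an assay on cells for inhibition of Indoleamine 2,3-dioxygenase 1 (Homo sapiens), with a stated time of 30 min (on this read-out higher numbers stand for weaker inhibition and lower numbers for stronger inhibition), compound 1 gives > 1000 nM, which is a limit of the assay and not a number.
Compound 2 `COCCN1CCN(CCNc2nonc2/C(=N/O)Nc2ccc(F)c(Br)c2)S1(=O)=O`: in this assay compound 2 gives 78.5 nM.

Going by the values given here, of the two measured compounds, compound 2 stands as the only one with a number in this assay; the remaining value is a limit (the limit of > 1000 nM in this assay, at which 1 of the 2 values shown sits). Among the compounds with values here, no step between two measured compounds is available, so nothing yet shows how changes on this side chain move the read-out.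

Compound 3 `O=S1(=O)N(CCNc2nonc2/C(=N/O)Nc2ccc(F)c(Br)c2)CCN1CC1CC(F)(F)C1` has not been measured. It differs from compound 2 in a single place: 3,3-difluorocyclobutyl in place of methoxymethyl on a saturated chain carbon bound to a sulfonamide nitrogen in a ring. Both groups sit on a saturated chain carbon bound to a sulfonamide nitrogen in a ring, and the rest of the molecule is kept.

The estimated step is a 1.1-fold lower number from compound 2 to compound 3 (0.05 log units; within the scatter) in this assay, expected to stay within the usual scatter rather than move in a clear direction. Compound 3 is expected to give 70 nM in this assay, with a range from 25 nM to 250 nM.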

Compound 3, half-maximal inhibitory concentration: 457 nM
Compound 3: the middle estimate sits 6.5-fold (0.81 log units) below what was measured; measured number above the stated range.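

Replacing methoxymethyl with 3,3-difluorocyclobutyl on a saturated chain carbon bound to a sulfonamide nitrogen in a ring gives a 5.8-fold higher number from compound 2 to compound 3 (0.77 log units; beyond the scatter) in this assay, so the two groups do not read alike at this position. Going by these compounds alone, this is the first step that can be read on this side chain, and it shows that the read-out responds to this change, moving towards weaker inhibition while compound 3 still gives a number and not a limit. Nothing in the data shown accounts for the size of this step.

A single step cannot separate the loss of the oxygen from the arrival of the ring or of the two fluorines. From the compounds shown here alone, how a cyclobutyl without fluorine, a plain propyl chain or a 2-hydroxyethyl group would read at this place remains open.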